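Swapping the Benzyl Substituent of Compound 3

The source may report more compounds than this note shows. Statements on the series, on what has been measured and on what is new or still open speak of the compounds shown alone.

Three compounds sharing one core were tested in a functional assay on BMMC cells (Mus musculus, strain C57BL/6) for inhibition, with stated times of 5 days and 48 h; on this read-out higher numbers stand for weaker inhibition and lower numbers for stronger inhibition. Compound 1 `C=C1CC[C@@H]2[C@](C)(CO)[C@H](O)CC[C@@]2(C)[C@@H]1CC=O` gives > 30000 nM, a limit of the assay and not a number. Compound 2 `C=C1CC[C@@H]2[C@](C)(CO)[C@H](O)CC[C@@]2(C)[C@@H]1C/C=C(/C(=O)O)[C@H](O)CO` likewise gives > 30000 nM, again a limit rather than a measured number. Within the data shown here, compound 3 `C=C1CC[C@@H]2[C@](C)(CNCc3ccc(OC)c(OC)c3)[C@H](O)CC[C@@]2(C)[C@@H]1/C=C/C1=CCOC1=O` is the only compound with a numerical result, 3740 nM in this assay, and so it stands apart from the limit of > 30000 nM in this assay, at which 2 of the 3 values shown sit. Among the measured compounds shown here, no step between two measured compounds can be drawn here, as compounds 1 and 2 return limits only.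

Compound 4 `C=C1CC[C@@H]2[C@](C)(CNCc3ccc(C#N)cc3)[C@H](O)CC[C@@]2(C)[C@@H]1/C=C/C1=CCOC1=O` has not yet been measured. It differs from compound 3 in one place: 4-cyanophenyl in place of 3,4-dimethoxyphenyl on a saturated chain carbon bound to an amine nitrogen. For the measured compounds named here, no measured pair shows the effect of such a change, so neither size nor direction of the step can be read from the data at hand. One would expect the step of a 1.3-fold higher number from compound 3 to compound 4 (0.13 log units; within the scatter) to remain within the scatter or to weaken inhibition modestly. Compound 4 is therefore estimated at 5000 nM in this assay, with a range from 1500 nM to 20000 nM.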

Compound 4, half-maximal inhibitory concentration: 1130 nM
The estimate for compound 4 lay 4.4-fold (0.65 log units) above the measured number, outside the stated range (below it).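

In this assay, among these compounds, the change on this saturated chain carbon bound to an amine nitrogen gives a 3.3-fold lower number from compound 3 to compound 4 (0.52 log units; beyond the scatter), the first step that can be read at all. The benzyl substituent can therefore be altered with inhibition retained and somewhat strengthened, and compound 4 shows that the two methoxy groups of 3,4-dimethoxybenzyl are not required for a numerical result. Nothing shown here accounts for the direction or size of this step.

The single change removes both methoxy groups and adds the nitrile, so the compounds shown leave open which of these matters. They also leave open how an unsubstituted benzyl, a 4-methoxybenzyl or a 4-chlorobenzyl group would compare in this assay.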